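This account rests on a few compounds, and the source may have more. Where it says the series, first, only, none or still open, it means among the compounds named here.

Among the compounds with values here, in an ADME assay on A549 cells (Homo sapiens) for cytotoxicity, read by LDH release, with a stated time of 15 h (a lower number here means that less compound is tolerated, a higher number that more compound is tolerated), compound 1 `CC1(Nc2ccc(NC(=O)c3cc(Cl)ccc3O)c(Cl)c2)CCCCC1` gives 86500 nM and compound 2 `CCCNc1ccc(NC(=O)c2cc(Cl)ccc2O)c(Cl)c1` gives 69700 nM, so compound 2 stands within the scatter of compound 1, the only other measured compound. Compound 3 `O=C(Nc1ccc(NCc2ccccc2)cc1Cl)c1cc(Cl)ccc1O` differs from compound 2 by phenyl in place of ethyl on a saturated chain carbon bound to a nitrogen on an aromatic ring, or propylamino to benzylamino. Within the data shown here, one measured step bears on this, since it also changed the group on that nitrogen, putting propyl in place of 1-methylcyclohexyl: a 1.2-fold lower number from compound 1 to compound 2 (0.09 log units; within the scatter). Among the measured compounds shown here, with only that step to go on, no shift beyond the scatter is expected in this assay, although no measured compound carries benzyl. The expected step is a 1.2-fold lower number from compound 2 to compound 3 (0.07 log units; within the scatter). For compound 3 the estimate is 60000 nM, with an expected range from 25000 nM to 120000 nM.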

Compound 3, half-maximal cytotoxic concentration: 81300 nM
Compound 3: the middle estimate sits 1.4-fold (0.13 log units) below what was measured; the measured number falls inside the stated range.
By their numbers in this assay, from the lowest: compounds 2, 3 and 1 (each within the scatter of the next).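

Putting phenyl in place of ethyl on a saturated chain carbon bound to a nitrogen on an aromatic ring brings one six-membered aromatic ring of carbon only into this group, and in this assay the step is small (a 1.2-fold higher number from compound 2 to compound 3 (0.07 log units; within the scatter)). Benzyl in place of 1-methylcyclohexyl on that nitrogen is equally small (a 1.1-fold lower number from compound 1 to compound 3 (0.03 log units; within the scatter)). Propyl, 1-methylcyclohexyl and benzyl thus all give numbers within the scatter of one another, now including a group with an aromatic ring, and nothing measured here accounts for this.

As far as these compounds go, whether a group carrying an amine or a carboxylic acid on this nitrogen would move the number beyond the scatter remains open. From the compounds shown here alone, all three compounds share the same core, so the effect of changes elsewhere on it also remains open.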